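Methoxy in Place of Methyl on Two Related Cores

A few compounds are considered here, and "the series" means these few. Any claim that something is new, unique, unknown or untested is made for them only; others in the source may bear on it.

Compound 1, `Cc1ccc2c(c1)-c1cnc(n1C)OCCCCCCCCO2`: 57000 nM
Compound 2, `COc1ccc2c(c1)-c1cnc(n1C)OCCCCCCCCO2`: 63000 nM
Compound 3, `C=CCCCCOc1ccc(C)cc1-c1cnc(OCCC=C)n1C`: 33000 nM

All three compounds were tested in a functional assay on U-373MG ATCC cells (Homo sapiens) for inhibition, read by colorimetric assay and MTT assay, with a stated time of 72 h; a higher number here means a weaker inhibitor, a lower number a stronger inhibitor. Compound 1 and compound 2 share one core and differ in a single place: methoxy in place of methyl on an aromatic carbon. That change gave the step of a 1.1-fold higher number from compound 1 to compound 2 (0.04 log units; within the scatter), so the two numbers cannot be told apart by this assay.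

Compound 3 carries a different core, in which the large ring of compound 1 is opened into two separate chains; how the two cores differ is not broken down here. Its value in this assay lies within the usual scatter of both compound 1 and compound 2, so no order among the three can be claimed.

Compound 4, `C=CCCCCOc1ccc(OC)cc1-c1cnc(OCCC=C)n1C`, has not yet been measured. It stands to compound 3 as compound 2 stands to compound 1: methoxy in place of methyl on an aromatic carbon. This is the same kind of change as before, though not at an identical place. In compound 1 the carbon that carries the group is part of a fused or bridged system of three rings, meta to a fused ring and para to a fused ring; in compound 3 it is meta to a large group and para to a (hex-5-en-1-yl)oxy group.

Within the data shown here, from compound 3 to compound 4 the step expected in this assay is a 1.1-fold higher number from compound 3 to compound 4 (0.04 log units; within the scatter), set beside the earlier step because a 1.1-fold higher number from compound 1 to compound 2 (0.04 log units; within the scatter) is the only measured example of this change. On that basis compound 4 is estimated at 36000 nM, with a likely range from 18000 nM to 72000 nM.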

Compound 4, half-maximal inhibitory concentration: 67000 nM
Compound 4: middle estimate off by 1.9-fold (0.27 log units), on the low side, within the range that was stated.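

In this assay, methoxy in place of methyl on the core with two separate chains gave a 2.0-fold higher number from compound 3 to compound 4 (0.31 log units; beyond the scatter), a modest step that lies beyond the usual scatter, whereas the same change on the core of compound 1 gave a step within it. Even so, the two steps cannot be told apart, since the gap between them is no larger than repeated measurements could produce: the same change on two cores in this assay, a 1.1-fold higher number (0.04 log units; within the scatter) from compound 1 to compound 2 and a 2.0-fold higher number (0.31 log units; beyond the scatter) from compound 3 to compound 4, 1.8-fold (0.26 log units) apart, within the scatter of two such steps

This means the data give no sign that the choice of core alters what this change does, but two pairs of compounds are too few to prove that it carries over unaltered from one core to the other, and they offer no explanation for either step.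

The compounds shown leave open what other groups on this same aromatic carbon would do in place of methyl or methoxy, such as a chlorine atom, a hydroxyl or an amine. Also open, from the compounds shown here alone, is whether the step would stay the same with a longer chain in place of the (hex-5-en-1-yl)oxy group.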